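The compounds below may be only part of what the source reports. "The series", "measured", "known", "first", "only" and "open" are said of these compounds alone.

Measured compounds:
Compound 1 `CCn1c(C(=O)NCCN)ccc1C(CC)(CC)c1ccc(OCCC(O)(CC)CC)c(C)c1` in a functional assay on MCF7 cells (Homo sapiens) for antiproliferative activity, read by MTT assay, with a stated time of 48 h (on this read-out higher numbers stand for weaker inhibition and lower numbers for stronger inhibition), gives 670 nM.
Compound 2 `C#CC(C)OC(=O)c1ccc(C(CC)(CC)c2ccc(OCCC(O)(CC)CC)c(C)c2)n1CC` in this assay gives only the assay's limit, > 50000 nM.

Compound 2 thus has no number of its own in this assay; what is known is that it sits at the limit (the limit of > 50000 nM in this assay, at which 1 of the 2 values shown sits). Compound 3 `CCn1c(C(=O)Nc2cccc(C(F)(F)F)c2)ccc1C(CC)(CC)c1ccc(OCCC(O)(CC)CC)c(C)c1` differs from compound 2 in one place: (3-(trifluoromethyl)phenyl)amino in place of (1-methylprop-2-yn-1-yl)oxy on a carbonyl carbon. For the measured compounds named here, the only measured step that bears on this change is the one from compound 1 to compound 2, which also exchanged a group on the same carbonyl carbon and gave an at least 74-fold higher number from compound 1 to compound 2 (1.87 log units; beyond the scatter). That step took away an amide and put an ester in its place, with a large loss of inhibition; the step to compound 3 runs the other way, bringing an amide back, though now carrying (3-(trifluoromethyl)phenyl)amino rather than the (2-aminoethyl)amino of compound 1. On that basis a large fall in the number is expected for compound 3 in this assay, estimated as an at least 16-fold lower number from compound 2 to compound 3 (1.22 log units; beyond the scatter). Compound 3 is therefore expected at 3000 nM, with a range from 500 nM to 20000 nM.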

Compound 3, half-maximal inhibitory concentration: > 50000 nM
Compound 3: no number, only a limit; the forecaster's own chance of this, stated with the estimate: 15%; middle value at least 16-fold (1.22 log units) from the limit.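

Putting an amide back on this carbonyl carbon does not by itself restore inhibition: in this assay compound 3, with (3-(trifluoromethyl)phenyl)amino at this place, gives > 50000 nM, which is a limit of the assay and not a number. With the amide kept and only the group on its nitrogen changed, 3-(trifluoromethyl)phenyl in place of 2-aminoethyl gives an at least 74-fold higher number from compound 1 to compound 3 (1.87 log units; beyond the scatter), so the group on the amide-type nitrogen matters here, not the amide alone. Compound 2 and compound 3 cannot be ranked against each other, and the step between them cannot be read, because both sit at the same limit: the limit of > 50000 nM in this assay, at which 2 of the 3 values shown sit.

Going by these compounds, of these three compounds only compound 1 gives a number, so it remains open whether the amine in its (2-aminoethyl)amino group or some other feature of that group accounts for its inhibition. A simple ethylamino group with no second amine, a longer chain ending in an amine, or a chain ending in a hydroxyl group on this carbonyl carbon would help separate these possibilities.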